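The source may hold more compounds than are shown below. What is called first, only, known or untested is meant among the compounds shown, and "the series" means these compounds.

Compound 1 `CCCc1nc(-c2ccccc2)c(CNCCCN2CCN(c3cccc(C)c3)CC2)o1` and compound 2 `CCCc1nc(-c2ccccc2)c(CNCCN2CCN(c3cccc(C(F)(F)F)c3)CC2)o1` share the same core. In an assay on HEK293 cells for inhibition of Voltage-dependent T-type calcium channel subunit alpha-1G (Homo sapiens), read by patch clamp (a higher number here means a weaker inhibitor, a lower number a stronger inhibitor), compound 1 gives 1190 nM, and in this assay compound 2 gives 1940 nM, the higher of the two numbers; the two values lie within the scatter of one another, so neither compound can be called the stronger inhibitor. The two structures differ in more than one place, so no single change separates them.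

Compound 3 `CCCc1nc(-c2ccccc2)c(CNCCN2CCN(c3ccccc3C(F)(F)F)CC2)o1` has not yet been measured. Compared with compound 2 it has 2-(trifluoromethyl)phenyl in place of 3-(trifluoromethyl)phenyl on an amine nitrogen in a ring. Going by the values given here, no measured pair shows a change of this kind, so the size of the step is uncertain; the change only moves the trifluoromethyl on the same phenyl, and a modest step toward a higher number, possibly no larger than the scatter, is expected. Compound 3 is expected to give 2600 nM in this assay, within 900 nM to 8000 nM. The expected step from compound 2 to compound 3 is a 1.3-fold higher number from compound 2 to compound 3 (0.13 log units; within the scatter).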

Compound 3, half-maximal inhibitory concentration: 2100 nM
Compound 3: the middle estimate sits 1.2-fold (0.09 log units) above what was measured; low and high end bracket the measured number.
By their numbers in this assay, from the lowest: compounds 1, 2 and 3 (each within the scatter of the next).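

Going by these compounds alone, this is the first single change that can be read: replacing 3-(trifluoromethyl)phenyl with 2-(trifluoromethyl)phenyl on the amine nitrogen in the ring gives a 1.1-fold higher number from compound 2 to compound 3 (0.03 log units; within the scatter) in this assay. The two groups have the same atoms joined differently, so for this pair, moving the trifluoromethyl around the phenyl ring has no effect that this measurement can separate from scatter. No available measurement bears on why the two compounds read alike.

As far as these compounds go, it remains open whether a different group on that phenyl, such as a methoxy or a chlorine, or a pyridine in place of the phenyl, would give a step beyond the scatter. Compound 1 differs from compound 2 in more than one place, so the contribution of its chain and that of its phenyl substituent cannot be read separately.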